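Two Aryl Swaps and an Expected Gain in Potency

The source may hold more compounds than are shown below. What is called first, only, known or untested is meant among the compounds shown, and "the series" means these compounds.

Three compounds built on a shared core were tested in a functional assay on B16-F10 cells (Mus musculus) for inhibition, read by MTT assay, with a stated time of 72 h; a lower number here means a stronger inhibitor, a higher number a weaker inhibitor. Compound 2 `COc1ccccc1Nc1nc(SCc2cn(CC(=O)NC(=O)Nc3ccccn3)nn2)nc(-c2ccc(C(C)C)cc2)c1C#N` gives 34600 nM. Compound 1 `Cc1ccc(Nc2nc(SCc3cn(CC(=O)NC(=O)Nc4ccccn4)nn3)nc(-c3ccc(C(C)C)cc3)c2C#N)cc1` gives 3060 nM. Compound 3 `COc1ccccc1Nc1nc(SCc2cn(CC(=O)NC(=O)Nc3ccccn3)nn2)nc(-c2ccc(C)cc2)c1C#N` gives 8580 nM.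

Two single changes connect these numbers. From compound 2 to compound 1 the change is 4-methylphenyl in place of 2-methoxyphenyl on a nitrogen on an aromatic ring, and it brought an 11-fold lower number from compound 2 to compound 1 (1.05 log units; beyond the scatter). From compound 2 to compound 3 the change is methyl in place of isopropyl on an aromatic carbon, and it brought a 4.0-fold lower number from compound 2 to compound 3 (0.61 log units; beyond the scatter). Compound 1 and compound 3 differ in two places at once, so their values are simply compared: compound 1 has the lower number.

Compound 4 `Cc1ccc(Nc2nc(SCc3cn(CC(=O)NC(=O)Nc4ccccn4)nn3)nc(-c3ccc(C)cc3)c2C#N)cc1` has not yet been measured. It stands to compound 3 as compound 1 stands to compound 2: 4-methylphenyl in place of 2-methoxyphenyl on a nitrogen on an aromatic ring. The place of the change reads the same in both pairs, so this is the same change, made on a core that differs only in the swap already told between compound 2 and compound 3. Compound 4 also differs from compound 1 only by that same core swap.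

The step from compound 3 to compound 4 is expected to be about the size of the earlier one, an 11-fold lower number from compound 3 to compound 4 (1.03 log units; beyond the scatter), because the same change gave an 11-fold lower number from compound 2 to compound 1 (1.05 log units; beyond the scatter) on the other core. Compound 4 is therefore expected to come in near 800 nM in this assay, with an estimated range from 300 nM to 2500 nM.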

Compound 4, half-maximal inhibitory concentration: 1010 nM
The estimate for compound 4 lay 1.3-fold (0.10 log units) below the measured number; the measured number falls inside the stated range.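

The swap to 4-methylphenyl carried over to the second core, where it gave an 8.5-fold lower number from compound 3 to compound 4 (0.93 log units; beyond the scatter), and the size of the step held up from one core to the other: the same change on two cores in this assay, an 11-fold lower number (1.05 log units; beyond the scatter) from compound 2 to compound 1 and an 8.5-fold lower number (0.93 log units; beyond the scatter) from compound 3 to compound 4, 1.3-fold (0.12 log units) apart, within the scatter of two such steps

The other change, methyl in place of isopropyl on an aromatic carbon, gave a 3.0-fold lower number from compound 1 to compound 4 (0.48 log units; beyond the scatter), and it too kept its size when the group on the nitrogen was different: the same change on two cores in this assay, a 4.0-fold lower number (0.61 log units; beyond the scatter) from compound 2 to compound 3 and a 3.0-fold lower number (0.48 log units; beyond the scatter) from compound 1 to compound 4, 1.3-fold (0.12 log units) apart, within the scatter of two such steps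

Within these four compounds in this assay, each change therefore acted much the same whichever form of the other group was present, but this rests on only one pair of steps per change and does not show why the numbers fall, nor whether the same would hold on other cores or in other cells.

The compounds shown leave open which part of the first swap matters, the loss of the methoxy group or the different place of the substituent, and a 2-methylphenyl or a 4-methoxyphenyl group on the same nitrogen would separate the two. They also leave open how far the second trend runs, for example with an ethyl group or a carboxylic acid on that aromatic carbon.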